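A dimethylphenyl amide and its pyridinyl counterpart

The source may hold more compounds than are shown below. What is called first, only, known or untested is meant among the compounds shown, and "the series" means these compounds.

The three measured compounds share one core and differ only in the aryl group on the carbonyl carbon. In an assay on HEK293 cells for displacement of a labelled ligand from metabotropic glutamate receptor 5 (Rattus norvegicus) (on this read-out higher numbers stand for weaker inhibition and lower numbers for stronger inhibition), compound 1 `O=C(Nc1cc(-c2ccccc2)nn1-c1ccccc1)c1cccc(C(F)(F)F)c1` gives 1650 nM. Compound 2 `Cc1ccc(C(=O)Nc2cc(-c3ccccc3)nn2-c2ccccc2)cc1` gives 780 nM in this assay, and compound 3 `Cc1ccc(C(=O)Nc2cc(-c3ccccc3)nn2-c2ccccc2)cc1C` gives 430 nM. The number falls by a 2.1-fold lower number from compound 1 to compound 2 (0.33 log units; beyond the scatter) and by a 3.8-fold lower number from compound 1 to compound 3 (0.58 log units; beyond the scatter), while the extra methyl gives only a 1.8-fold lower number from compound 2 to compound 3 (0.26 log units; within the scatter). Compound 3 thus holds the lowest number of the three, though its gap to compound 2 is within the scatter, so only its distance to compound 1 counts as a real difference.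

Compound 4 `O=C(Nc1cc(-c2ccccc2)nn1-c1ccccc1)c1ccncc1` carries pyridin-4-yl in place of 3,4-dimethylphenyl on a carbonyl carbon. Within the data shown here, no measured step involves a pyridin-4-yl group, so none bears on it directly; the steps at this position show that swapping the aryl group moves the number by a modest amount, and the step from compound 2 to compound 3 shows that the two methyl groups by themselves changed little beyond the scatter. A ring with one hetero atom is a larger departure than any measured here, and the range must be wide. The estimate is that compound 4 gives 2000 nM in this assay, between 600 nM and 7000 nM. That corresponds to an expected step of a 4.7-fold higher number from compound 3 to compound 4 (0.67 log units; beyond the scatter), toward a higher number.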

Compound 4, inhibition constant: > 10000 nM
Compound 4: only a limit was reported (the forecaster's own chance of this, stated with the estimate: 15%); middle value at least 5.0-fold (0.69 log units) away from the limit.
By their numbers in this assay, from the lowest: compounds 3 and 2 (each within the scatter of the next); then compound 1. At a limit, above all of these: compound 4.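

In this assay compound 4 gives > 10000 nM, which is a limit of the assay and not a number. Measured against that limit, putting pyridin-4-yl on the carbonyl carbon gives an at least 23-fold higher number from compound 3 to compound 4 (1.36 log units; beyond the scatter), an at least 12-fold higher number from compound 2 to compound 4 (1.10 log units; beyond the scatter) and an at least 6.0-fold higher number from compound 1 to compound 4 (0.78 log units; beyond the scatter), so all three carbon-only aryl groups stand apart from it by steps beyond the scatter, two of them large. Among these compounds, the earlier compounds showed this position only with a six-membered aromatic ring of carbon only, where the swaps moved the number modestly at most; compound 4, the one compound here with a hetero atom in that ring, shows that the position does not accept every six-membered aromatic ring alike.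

Compound 4 differs from the others both in its ring nitrogen and in carrying no methyl or trifluoromethyl on the ring, so the compounds shown cannot say which of the two matters, and a plain phenyl group on the carbonyl carbon would separate them. As far as these compounds go, a methylpyridinyl group would test whether methyl restores the number with the ring nitrogen in place, and how far compound 4 lies past its limit also stays open.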